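Methyl for hydrogen on the aryl ring of compound 2

The source may hold more compounds than are shown below. What is called first, only, known or untested is meant among the compounds shown, and "the series" means these compounds.

Among the measured compounds shown here, compound 2 `O=C1CCC2(c3ccccc3)OCCCN12` is the only member of the series with a full number in a functional assay on the whole organism (Central nervous system) with Mus musculus as the target; a higher number here means that more compound is needed for the effect, a lower number that less compound is needed: compound 2 gives 150 mg/kg. Compound 1 `COc1ccc(C23CCC(=O)N2CCCO3)cc1` reaches only a limit of the assay in this assay, where compound 1 gives < 150 mg/kg. For the measured compounds named here, the one measured step is a number no lower from compound 1 to compound 2 (the limit leaves the size open), its size left open because of the limit of < 150 mg/kg in this assay, at which 1 of the 2 values shown sits. Compound 3 `Cc1ccc(C23CCC(=O)N2CCCO3)cc1` carries methyl in place of hydrogen on an aromatic carbon. Going by the values given here, the only step touching this ring position is the one just described, and it fixes neither a size nor a firm direction, so it gives no ground for a methyl to move the number more than the usual scatter. The expected step is a 1.3-fold lower number from compound 2 to compound 3 (0.10 log units; within the scatter), within the scatter. Compound 3 is estimated at 120 mg/kg, with a range from 60 mg/kg to 250 mg/kg.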

Compound 3, dose for half-maximal effect: 160 mg/kg
Beside the measured number, compound 3's estimate is 1.3-fold (0.12 log units) below it; the range from low to high includes it.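

In this assay, among the compounds shown here, a size can be read at this ring position for the first time, for methyl in place of hydrogen: a 1.1-fold higher number from compound 2 to compound 3 (0.03 log units; within the scatter). A methyl para to a large group on the aromatic ring therefore does not separate these two compounds beyond the scatter. Methyl in place of methoxy gives an at least 1.0-fold higher number from compound 1 to compound 3 (0.02 log units; that floor lies within the scatter), which is only a floor, and the true size stays open: the limit of < 150 mg/kg in this assay, at which 1 of the 3 values shown sits.

Still open, as far as these compounds go, is whether any group on this aromatic carbon moves the number beyond the scatter. An amine, a carboxylic acid or a chlorine atom here, or a longer chain in place of the methyl, would test this in this assay.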